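Octylsulfanyl in Place of 2-Methoxyethoxy on the Shared Core

A few compounds are considered here, and "the series" means these few. Any claim that something is new, unique, unknown or untested is made for them only; others in the source may bear on it.

Measured so far:
Compound 1 `COCCOc1nc(N)nc2c1ncn2/C=C1/CC1(CO)CO`; in an ADME assay on HFF cells (Homo sapiens) for cytotoxicity, with a stated time of 8 days (a higher number here means that more compound is tolerated, a lower number that less compound is tolerated), compound 1 gives > 300000 nM, a limit of the assay.
Compound 2 `Nc1nc2c(ncn2/C=C2/CC2(CO)CO)c(=O)[nH]1`; in this assay compound 2 gives > 300000 nM, again a limit of the assay.

Compound 1 therefore stands where every value shown stands: at the limit of > 300000 nM in this assay, at which 2 of the 2 values shown sit. Within the data shown here, no step between measured compounds is available, so the numbers give no direction of their own.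

Compound 3 `CCCCCCCCSc1nc(N)nc2c1ncn2/C=C1/CC1(CO)CO` differs from compound 1 by octylsulfanyl in place of 2-methoxyethoxy on an aromatic carbon. Among the measured compounds shown here, with no measured step to lean on, the size of the change in this assay is uncertain; the octylsulfanyl chain is a larger group than the one it replaces, and a step toward a lower number, beyond the scatter, is expected, though a limit may again be reported. The expected step is an at least 3.0-fold lower number from compound 1 to compound 3 (0.47 log units; beyond the scatter). For compound 3 the estimated value in this assay is 100000 nM, with a range from 20000 nM to 300000 nM.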

Compound 3, half-maximal cytotoxic concentration: > 300000 nM
Compound 3 was reported as a limit (the forecaster's own chance of this, stated with the estimate: 40%); middle value at least 3.0-fold (0.47 log units) away from the limit.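

Compound 1 and compound 3 both stand at a limit in this assay, so no step can be read between them: the limit of > 300000 nM in this assay, at which 3 of the 3 values shown sit.

The compounds shown leave open whether octylsulfanyl in place of 2-methoxyethoxy changes the read-out at all, and what number any compound would give short of that limit.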